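The source may hold more compounds than are shown below. What is called first, only, known or untested is meant among the compounds shown, and "the series" means these compounds.

Measured in an ADME assay on CHO cells (Cricetulus griseus) for inhibition, read by MTT assay; on this read-out lower numbers stand for stronger inhibition and higher numbers for weaker inhibition:
- Compound 1 `CC(C)(C)NCc1cc(Cl)cc(Nc2nc3cc(F)c(F)cc3n2Cc2ccc(C(F)(F)F)cc2)c1O`: > 50000 nM (a limit)
- Compound 2 `CCNCc1cc(Cl)cc(Nc2nc3cc(F)c(F)cc3[nH]2)c1O`: > 50000 nM (a limit)

Compound 2 gives > 50000 nM, which is a limit of the assay and not a number. Both measured compounds share this position: the limit of > 50000 nM in this assay, at which 2 of the 2 values shown sit. Compound 3 `CC(C)(C)NCc1cc(Cl)cc(Nc2nc3cc(F)c(F)cc3[nH]2)c1O` differs from compound 2 by one change: tert-butyl in place of ethyl on an amine nitrogen. Compound 1 also carries tert-butyl on an amine nitrogen and stands at the limit of > 50000 nM. For the measured compounds named here, no measured step is available in this assay, so the expected change, a number no higher from compound 2 to compound 3 (the limit leaves the size open), is none beyond the scatter. Compound 3 is estimated at 50000 nM, within an expected range from 25000 nM to 100000 nM.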

Compound 3, half-maximal inhibitory concentration: 39700 nM
Compound 3: middle estimate off by 1.3-fold (0.10 log units), on the high side; measured number inside the range.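

In this assay, compound 3 is the first compound to give a number and not a limit, while the other two stay at a limit: the limit of > 50000 nM in this assay, at which 2 of the 3 values shown sit.

Putting tert-butyl in place of ethyl on the amine nitrogen gives an at least 1.2-fold lower number from compound 2 to compound 3 (0.10 log units; that floor lies within the scatter). Putting hydrogen in place of 4-(trifluoromethyl)benzyl on the aromatic nitrogen gives an at least 1.2-fold lower number from compound 1 to compound 3 (0.10 log units; that floor lies within the scatter). Going by these compounds, both are only floors, so the true size of each change remains unknown.

On these data alone, how isopropyl or a longer chain on the amine nitrogen would read in this assay remains open.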